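Removing One Fluorine in a Cytotoxicity Series

The source may report more compounds than this note shows. Statements on the series, on what has been measured and on what is new or still open speak of the compounds shown alone.

The three measured compounds, all tested in an ADME assay on Karpas-1106P cells (Homo sapiens) for cytotoxicity (on this read-out higher numbers stand for an effect only at larger amounts of compound and lower numbers for an effect already at smaller amounts), are:

Compound 1 `Cc1ccc(S(=O)(=O)N[C@@H](CC(=O)NC(C)(C)C)C(=O)NCCNC(=O)NCc2ccccc2)cc1`, which reaches only the limit of this assay, > 11100 nM.
Compound 2 `Cc1ccc(S(=O)(=O)N[C@@H](CC(=O)NC(C)(C)C)C(=O)NCCNC(=O)c2cccc(O)c2)cc1`, which also reaches only the limit, > 11100 nM.
Compound 3 `Cc1ccc(S(=O)(=O)N[C@@H](CC(=O)NC(C)(C)C)C(=O)NCCNC(=O)c2ccc(F)c(F)c2)cc1`, which likewise reaches only the limit, > 11100 nM.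

Compound 3 therefore stands where every value in this set stands: at the limit of > 11100 nM in this assay, at which 3 of the 3 values shown sit. Within the data shown here, no compound gives a number, so the steps between them cannot be read; a step that the two limits leave unreadable from compound 1 to compound 3 and a step that the two limits leave unreadable from compound 2 to compound 3 are both unreadable, and the same holds for a step that the two limits leave unreadable from compound 1 to compound 2.

The next compound, compound 4 `Cc1ccc(S(=O)(=O)N[C@@H](CC(=O)NC(C)(C)C)C(=O)NCCNC(=O)c2ccc(F)cc2)cc1`, differs from compound 3 by hydrogen in place of fluoro on an aromatic carbon. Since every measured value in this assay sits at the limit, there is no readable step on which to base a direction, and the likeliest outcome is that compound 4 also shows no effect within the measured range. Compound 4 is therefore expected to give about 15000 nM, with a range from 11100 nM to 40000 nM, most probably reported again as a limit. The expected step that the limit leaves unreadable from compound 3 to compound 4 is thus not one beyond the scatter.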

Compound 4, half-maximal effective concentration: > 11100 nM
Compound 4: no number, only a limit; the forecaster's own chance of this, stated with the estimate: 85%; the middle value does not contradict the limit.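

Among these compounds, no step among compound 1, compound 2, compound 3 and compound 4 can be read, since each gives only a limit and no number: the limit of > 11100 nM in this assay, at which 4 of the 4 values shown sit. Going by these compounds, what stays open is whether any of them shows an effect in this assay at larger amounts, and how far they would then differ.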